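Dimethyl oxolane variant of compound 1: stability notes

A few compounds are considered here, and "the series" means these few. Any claim that something is new, unique, unknown or untested is made for them only; others in the source may bear on it.

Measured so far:
compound 1 `COc1cc(-c2cnn3cc(OC)c(C4CCOC4)nc23)ccn1`: 34%
compound 2 `Cn1cc(-c2nc3c(-c4ccnc(OC5CC5)c4)cnn3cc2OCCCC(C)(C)O)cn1`: 64%

In an ADME assay on microsomes from liver (Rattus norvegicus) for metabolic stability, with a stated time of 60 min, tested at 1 uM (on this read-out higher numbers stand for a more stable compound and lower numbers for a less stable compound), compound 1 gives 34%, the lowest of the two numbers at hand. Among the measured compounds shown here, compound 2 gives 64%, a number beyond the scatter higher; no step between these two has been worked out, so only the two values stand.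

Compound 3 `COc1cc(-c2cnn3cc(OC)c([C@H]4COC(C)(C)C4)nc23)ccn1` differs from compound 1 by a group of 7 heavy atoms (6 carbon, 1 oxygen; one five-membered non-aromatic ring with 1 hetero atom) in place of a group of 5 heavy atoms (4 carbon, 1 oxygen; one five-membered non-aromatic ring with 1 hetero atom), on an aromatic carbon. For the measured compounds named here, no measured pair shows a change of this kind, so the step is open. A small upward move, close to the scatter, is expected; the estimated step is a number 6 percentage points higher from compound 1 to compound 3 (within the scatter). Compound 3 is expected at 40%, with a range from 20% to 65%.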

Compound 3, percent of the compound remaining: 30%
The estimate for compound 3 lay 10 percentage points above the measured number, within the range that was stated.
By their numbers in this assay, from the lowest: compounds 3 and 1 (each within the scatter of the next); then compound 2.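

In this assay the group of 7 heavy atoms in place of oxolan-3-yl, on the aromatic carbon next to the ring nitrogen, gives a number 4 percentage points lower from compound 1 to compound 3 (within the scatter) and so leaves the read-out unresolved between the two compounds. This position therefore accepts the larger five-membered ring without a step beyond the scatter. Nothing at hand accounts for this result.

Open, from the compounds shown here alone, is whether an amine or a carboxylic acid on this ring would move the read-out beyond the scatter. Compound 2 differs from compound 1 in more than one place, so its value cannot be assigned to this position.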